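An Ethoxycarbonyl Group Replaces 4-Fluoro-3-nitrophenyl

The source may report more compounds than this note shows. Statements on the series, on what has been measured and on what is new or still open speak of the compounds shown alone.

In a functional assay on MV4-11 cells (Homo sapiens) for antiproliferative activity, read by luminescence and CellTiter-Glo, with a stated time of 72 h (on this read-out lower numbers stand for stronger inhibition and higher numbers for weaker inhibition), compound 1 `COc1ccc(Nc2nn(Cc3ccc(C)cc3)c3cc(-c4c(C)noc4C)ccc23)cc1` gives 11900 nM and compound 2 `COc1cc2cnn(Cc3ccc(F)cc3)c2cc1-c1c(C)noc1C` gives 1900 nM. Compound 3 `CNc1cc(-c2ccc3cnn(Cc4ccc(F)c([N+](=O)[O-])c4)c3c2)cn(C)c1=O` has the lowest number of the three at 130 nM, and the gaps to both others lie beyond the scatter. Compound 4 `CCOC(=O)Cn1ncc2ccc(-c3cc(NC)c(=O)n(C)c3)cc21` carries ethoxycarbonyl in place of 4-fluoro-3-nitrophenyl on a saturated chain carbon bound to an aromatic nitrogen. For the measured compounds named here, no measured pair isolates this change, so any forecast is uncertain. In this assay a rise in the number, beyond the scatter, is expected, estimated as a 12-fold higher number from compound 3 to compound 4 (1.06 log units; beyond the scatter). For compound 4 the estimated value is 1500 nM, with an expected range of 350 nM to 7000 nM.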

Compound 4, half-maximal inhibitory concentration: 8770 nM
Compound 4: middle estimate off by 5.8-fold (0.77 log units), on the low side; the measured number lies above the stated range.
By their numbers in this assay, from the lowest: compound 3; then compound 2; then compounds 4 and 1 (each within the scatter of the next).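

In this assay, for the compounds shown here, ethoxycarbonyl in place of 4-fluoro-3-nitrophenyl on a saturated chain carbon bound to an aromatic nitrogen gives a 67-fold higher number from compound 3 to compound 4 (1.83 log units; beyond the scatter), the first reading of this position in a single-change pair. The step is large although the two groups have the same counts of hydrogen-bond donors and acceptors; what leaves is the six-membered aromatic ring, and the group that enters has fewer heavy atoms. Nothing measured here accounts for the size of this step.

The compounds shown leave open whether the ring itself or its fluorine and nitro groups matter. They also do not tell how an unsubstituted phenyl, a carboxylic acid or a longer chain would read at this position.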